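From Compound 2 to Compound 3: A Ketone Side Chain Change

The source may report more compounds than this note shows. Statements on the series, on what has been measured and on what is new or still open speak of the compounds shown alone.

Of the compounds shown here, two sharing one core have so far been tested in an ADME assay on L929 cells (Mus musculus) for cytotoxicity, read by resazurin assay, with a stated time of 72 h; a lower number here means a stronger inhibitor, a higher number a weaker inhibitor. Compound 1 has the structure `CNC(=O)c1cccn1-c1ccc2c(c1)B(O)OC2`. In this assay compound 1 gives > 10 ug/mL, which is a limit of the assay rather than a measured number. Compound 2 has the structure `O=C(c1ccn(-c2ccc3c(c2)B(O)OC3)c1)c1ccccc1Cl`, carrying a 2-chlorophenyl on a carbonyl carbon whose other neighbour is an aromatic carbon. In this assay compound 2 gives > 10 ug/mL, again a limit and not a number. Compound 2 thus stands at the limit of > 10 ug/mL in this assay, at which 2 of the 2 values shown sit, so no difference between the two compounds can be read from the numbers shown.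

Compound 3, with the structure `CCCCCC(=O)c1ccn(-c2ccc3c(c2)B(O)OC3)c1`, has not yet been measured. It differs from compound 2 in one place: pentyl in place of 2-chlorophenyl on a carbonyl carbon. Going by the values given here, no step between measured compounds is available to guide the size of this change. Because compound 2 sits at the limit of > 10 ug/mL in this assay, at which 2 of the 2 values shown sit, the expected step is a step that the limit leaves unreadable from compound 2 to compound 3, with no direction beyond the usual scatter. Compound 3 is therefore estimated at 12 ug/mL, within a range from 5 ug/mL to 30 ug/mL.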

Compound 3, half-maximal inhibitory concentration: > 10 ug/mL
Compound 3: only a limit was reported; the forecaster's own chance of this, stated with the estimate: 70%; the middle value does not contradict the limit.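

Compound 3, like compound 2, gives only a limit and not a number, so no step between compound 2 and compound 3 can be read in this assay: the limit of > 10 ug/mL in this assay, at which 3 of the 3 values shown sit.

The compounds shown leave open whether pentyl in place of 2-chlorophenyl on a carbonyl carbon changes cytotoxicity at all, and by how much.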